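This account rests on a few compounds, and the source may have more. Where it says the series, first, only, none or still open, it means among the compounds named here.

Measured compounds in a functional assay on DU-145 cells (Homo sapiens) for cytotoxicity, read by CCK-8 assay and cell counting, with a stated time of 2 days; a higher number here means a weaker inhibitor, a lower number a stronger inhibitor:
compound 1, `Oc1ccc(-c2cc(-c3cccs3)nc(-c3ccccc3Cl)c2)cc1`: 4190 nM
compound 2, `Oc1cccc(-c2cc(-c3ccsc3)nc(-c3cccc(Cl)c3)c2)c1`: 3330 nM
compound 3, `Oc1cccc(-c2cc(-c3ccccc3)nc(-c3ccc(Cl)cc3)c2)c1`: 11200 nM

Compound 1 stands second highest of the three numbers. Its nearest neighbour is compound 2, whose value lies within the scatter of that of compound 1, so no order between the two can be read. Compound 3 stands furthest from compound 1, beyond the scatter, and carries the highest number of the three. Among the measured compounds shown here, no two measured compounds differ in only one place, so no single step has been isolated in this set.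

Compound 4, `Oc1ccc(-c2cc(-c3ccsc3)nc(-c3ccccc3Cl)c2)cc1`, is not yet measured. It differs from compound 1 in one place: thiophen-3-yl in place of thiophen-2-yl on an aromatic carbon. Compound 2 already carries a thiophen-3-yl group, but it differs from compound 1 in other places too, so its value gives no clean read on this change alone. With nothing in the series pointing either way, the step in this assay from compound 1 to compound 4 is expected to be small, in no fixed direction, and not beyond the scatter, that is, a 1.1-fold lower number from compound 1 to compound 4 (0.03 log units; within the scatter). For compound 4 the expected value is 3900 nM, with a range from 1800 nM to 8500 nM.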

Compound 4, half-maximal inhibitory concentration: 3890 nM
Compound 4: middle estimate off by 1.0-fold (0.00 log units), on the high side; the range from low to high includes it.
By their numbers in this assay, from the lowest: compounds 2, 4 and 1 (each within the scatter of the next); then compound 3.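

Among the compounds shown here, the only single-place step so far, read in this assay, is a 1.1-fold lower number from compound 1 to compound 4 (0.03 log units; within the scatter) for thiophen-3-yl in place of thiophen-2-yl on an aromatic carbon next to the ring nitrogen. At this position, with the 2-chlorophenyl and 4-hydroxyphenyl groups held fixed, the two thiophene attachments cannot be told apart, so where the sulfur sits in this five-membered ring has no readable effect on the number. No measured evidence on the cause of this result is available.

Open, as far as these compounds go, is whether a group of another kind at this position, such as an amine or a carboxylic acid, would move the number beyond the scatter. Also open, from the compounds shown here alone, is what the placement of the chlorine and the hydroxyl contributes, as compound 2 and compound 3 differ from compound 1 in more than one place.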